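Trimming the Sulfonyl Chain from Ethyl to Methyl

The compounds below may be only part of what the source reports. "The series", "measured", "known", "first", "only" and "open" are said of these compounds alone.

Three compounds have been measured in an assay on CHO cells for displacement of a labelled ligand from prostaglandin D2 receptor 2 (Homo sapiens), read by scintillation counting; on this read-out higher numbers stand for weaker inhibition and lower numbers for stronger inhibition:
Compound 1, `CCCS(=O)(=O)c1cc(C#Cc2cc(Cl)ccc2OCC(=O)O)c(C)cc1NC(C)=O`, gives 1.3 nM.
Compound 2, `CCS(=O)(=O)c1ccc(C)c(C#Cc2cc(Cl)ccc2OCC(=O)O)c1`, gives 8.6 nM.
Compound 3, `CCCS(=O)(=O)c1cccc(C#Cc2cc(F)ccc2OCC(=O)O)c1`, gives 65 nM.

Among these three numbers in this assay, compound 2 stands second highest. Its nearest neighbour is compound 1, whose number is the lower of the two by a margin beyond the usual scatter; furthest from it is compound 3, whose number is higher, again by a margin beyond the scatter. No two of the three measured compounds differ in only one place, so none of these gaps can be laid to a single structural change.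

Compound 4, `Cc1ccc(S(C)(=O)=O)cc1C#Cc1cc(Cl)ccc1OCC(=O)O`, has not yet been measured. It differs from compound 2 by hydrogen in place of methyl on a saturated chain carbon bound to a sulfonyl sulfur. Seen one bond further out, the change reads ethyl to methyl, or ethylsulfonyl to methylsulfonyl.

For the measured compounds named here, no measured pair shows this change, so the size of the step in this assay has to be judged from the change alone. A small step is expected, if any, towards a higher number, most likely within the scatter of repeated measurements. The expected step is a 1.4-fold higher number from compound 2 to compound 4 (0.14 log units; within the scatter). Compound 4 is accordingly estimated to give 12 nM, with an expected range from 5 nM to 30 nM.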

Compound 4, inhibition constant: 5 nM
Compound 4: middle estimate off by 2.4-fold (0.38 log units), on the high side; the measured number falls inside the stated range.
By their numbers in this assay, from the lowest: compound 1; then compounds 4 and 2 (each within the scatter of the next); then compound 3.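

In this assay, the change from ethylsulfonyl to methylsulfonyl gives a 1.7-fold lower number from compound 2 to compound 4 (0.24 log units; within the scatter), so replacing methyl with hydrogen on the saturated chain carbon bound to the sulfonyl sulfur produces no step beyond the usual scatter on this core. Compounds 2 and 4 are the only pair among those shown that differ in one place, and they therefore give the only gap here that can be laid to a single structural change, whereas the earlier comparisons each mixed several differences. Nothing further is available to explain why the two compounds read alike in this assay.

The compounds shown leave open how a propyl chain, as carried by compound 1 and compound 3, or a still longer chain, would read on the core shared by compound 2 and compound 4, and how an amine or a cyclopropyl group in place of the chain on the sulfonyl sulfur would read there. They also leave open whether the change from ethyl to methyl would stay within the scatter on the core of compound 1 or on the core of compound 3.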